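Swapping the imidazole of compound 1 for an aminopyridine

The source may hold more compounds than are shown below. What is called first, only, known or untested is meant among the compounds shown, and "the series" means these compounds.

Measured compounds:
- compound 1, `Cc1cc(C)c(-c2ncc[nH]2)cc1NC(=O)c1ccc(OCc2ccccn2)cc1`, 2000 nM
- compound 2, `Cc1cc(C)c(-c2c(C)nn(C)c2C)cc1NC(=O)c1ccc(OCc2ccccn2)cc1`, 35000 nM
- compound 3, `Cc1cc(C)c(-c2ccccn2)cc1NC(=O)c1ccc(OCc2ccccn2)cc1`, a limit of the assay rather than a number

In a physicochemical assay for solubility, at pH 7.4 (a higher number here means a more soluble compound, a lower number a less soluble compound), compound 1 gives 2000 nM. Among the numbers shown it stands lowest of two, with compound 2 nearest by way of an 18-fold higher number from compound 1 to compound 2 (1.24 log units; beyond the scatter). For compound 3 the assay reports only a limit, < 1000 nM, one of the values sitting at the limit of < 1000 nM in this assay, at which 1 of the 3 values shown sits.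

The compound not yet measured is compound 4, `Cc1cc(C)c(-c2cccc(N)n2)cc1NC(=O)c1ccc(OCc2ccccn2)cc1`. It differs from compound 1 by 6-aminopyridin-2-yl in place of 1H-imidazol-2-yl on an aromatic carbon.

For the measured compounds named here, two measured steps bear on this change. The step of an at least 2.0-fold lower number from compound 1 to compound 3 (0.30 log units; that floor lies within the scatter) replaces the same imidazole with a plain pyridine and is the closest comparison. The step of an 18-fold higher number from compound 1 to compound 2 (1.24 log units; beyond the scatter) moves in the other direction but with a very different five-membered ring, so it speaks less directly to compound 4. Since compound 3 gives only a limit, the pyridine change cannot be sized firmly; compound 4 carries an extra amino group on that pyridine, which the data do not isolate. The expected step is therefore small and uncertain in direction, no change at the digits printed from compound 1 to compound 4 (within the scatter), within the scatter.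

The estimate for compound 4 is thus 2000 nM, expected to fall between 700 nM and 6000 nM.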

Compound 4, solubility: 2000 nM
Beside the measured number, compound 4's estimate shows no gap at the digits printed; the range from low to high includes it.
By their numbers in this assay, from the lowest: compounds 1 and 4 (each within the scatter of the next); then compound 2. At a limit, below all of these: compound 3.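

In this assay, the group on this aromatic carbon, ortho to one methyl group and para to another, can change from a five-membered to a six-membered aromatic ring with no change at the digits printed from compound 1 to compound 4 (within the scatter), while the comparison with the other five-membered group shows an 18-fold lower number from compound 2 to compound 4 (1.24 log units; beyond the scatter). Thus 6-aminopyridin-2-yl sits with 1H-imidazol-2-yl, and of the groups with a firm number, only 1,3,5-trimethyl-1H-pyrazol-4-yl stands apart. The amino group alone gives an at least 2.0-fold higher number from compound 3 to compound 4 (0.30 log units; that floor lies within the scatter), but compound 3 has a limit and not a number, so this step is only a floor: the limit of < 1000 nM in this assay, at which 1 of the 4 values shown sits.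

Going by these compounds, the true size of the amino step therefore stays open, and it cannot be said how much of the value of compound 4 depends on that group. Also open, on these data alone, is how a methylamino or dimethylamino group, or a hydroxyl or methoxy group, in place of amino on the pyridine would read, and whether the three methyl groups on the pyrazole or the ring itself set compound 2 apart.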